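The source may hold more compounds than are shown below. What is called first, only, known or untested is meant among the compounds shown, and "the series" means these compounds.

In an ADME assay on HeLa cells (Homo sapiens) for cytotoxicity, read by sulforhodamine B assay, with a stated time of 48 h, tested at 10 uM (a higher number here means more inhibition at the concentration tested (going by the name of the read-out), a lower number less inhibition), compound 3 `COc1nc2ccc(Br)cc2cc1C(c1ccccc1)n1cc(CO)nn1` gives 0.25% and stands at the low end of the three numbers shown: compound 2 `COc1nc2ccc(Br)cc2cc1C(c1ccccc1)n1cc(CCO)nn1` gives 0.85%, which lies within the scatter of it, while compound 1 `COc1nc2ccc(Br)cc2cc1C(c1ccccc1)n1cc(-c2ccccc2F)nn1` gives 14.1%, beyond the scatter. Compound 4 `COc1nc2ccc(Br)cc2cc1C(c1ccccc1)n1cc(-c2ccccc2C(F)(F)F)nn1` differs from compound 3 by 2-(trifluoromethyl)phenyl in place of hydroxymethyl on an aromatic carbon. The step that bears on this is a number 13.9 percentage points lower from compound 1 to compound 3 (beyond the scatter), a modest fall when 2-fluorophenyl gave way to hydroxymethyl; the step of a number 0.6 percentage points lower from compound 2 to compound 3 (within the scatter) stayed within the scatter. Putting an aromatic ring back in place of hydroxymethyl is expected to reverse that modest fall. The expected step is a number 14.8 percentage points higher from compound 3 to compound 4 (beyond the scatter). Compound 4 is estimated at 15%, with a range from 3% to 30%.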

Compound 4, a percentage reported as inhibition, at one concentration (the size of the read-out at that concentration, not a potency): -1.3%
The estimate for compound 4 lay 16.3 percentage points above the measured number; measured number below the stated range.
By their numbers in this assay, from the lowest: compounds 4, 3 and 2 (each within the scatter of the next); then compound 1.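

An aromatic ring at this position does not by itself raise the number in this assay: 2-(trifluoromethyl)phenyl reads the same as hydroxymethyl (a number 1.6 percentage points lower from compound 3 to compound 4 (within the scatter)) and 2-hydroxyethyl (a number 2.2 percentage points lower from compound 2 to compound 4 (within the scatter)). The group carried on that ring matters instead, since trifluoromethyl in place of fluoro gives a step beyond the scatter (a number 15.4 percentage points lower from compound 1 to compound 4 (beyond the scatter)). Nothing available explains this difference. Open, as far as these compounds go, is whether unsubstituted phenyl, or a chloro group on that ring, would side with compound 1 or compound 4. From the compounds shown here alone, an amine or a carboxylic acid on this carbon also remains untested here.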